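Notes on the step to compound 4

This account rests on a few compounds, and the source may have more. Where it says the series, first, only, none or still open, it means among the compounds named here.

In a functional assay on A-375 cells (Homo sapiens) for cytotoxicity, read by MTT assay, with a stated time of 72 h (on this read-out lower numbers stand for stronger inhibition and higher numbers for weaker inhibition), compound 1 (`O=C1c2c[n+]([O-])c3ccccc3c2C(=O)c2c1c1ccccc1n2CCCCn1ccnc1`) reads 350 nM and compound 2 (`CC1(C)OCC(Cn2cc(Cn3c4c(c5ccccc53)C(=O)c3c[n+]([O-])c5ccccc5c3C4=O)nn2)O1`) reads 330 nM while compound 3 (`CN1CCN(CCCn2c3c(c4ccccc42)C(=O)c2c[n+]([O-])c4ccccc4c2C3=O)CC1`) reads 470 nM on the same scale. The number for compound 2 lies within the scatter of both others, so the three cannot be ranked.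

Compound 4 (`O=C1c2c[n+]([O-])c3ccccc3c2C(=O)c2c1c1ccccc1n2Cc1cn([C@H]2C[C@H](O)[C@@H](CO)O2)nn1`) carries 4-hydroxy-5-(hydroxymethyl)oxolan-2-yl in place of (2,2-dimethyl-1,3-dioxolan-4-yl)methyl on an aromatic nitrogen. For the measured compounds named here, no measured step covers this exchange. Going by the values given here, the one step available (a 1.3-fold higher number from compound 1 to compound 3 (0.13 log units; within the scatter)) concerns a different substituent on a saturated chain carbon and stays within the scatter, so it bears only indirectly. Among the compounds with values here, with that step and the close values of compound 1, compound 2 and compound 3 as the only guide, no large shift is expected, though the evidence is thin. The estimated step (a 1.4-fold higher number from compound 2 to compound 4 (0.13 log units; within the scatter)) leans weakly towards a higher number and stays within the scatter. For compound 4 the expected value is 450 nM with an estimated range of 150 nM to 1300 nM for now.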

Compound 4, half-maximal inhibitory concentration: 390 nM
Estimate against measurement, compound 4: 1.2-fold (0.06 log units) above; the range from low to high includes it.
By their numbers in this assay, from the lowest: compounds 2, 1, 4 and 3 (each within the scatter of the next).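

In this assay, the exchange on an aromatic nitrogen of the five-membered aromatic ring with 3 nitrogen gives a 1.2-fold higher number from compound 2 to compound 4 (0.07 log units; within the scatter), a step within the scatter, so the read-out does not tell 4-hydroxy-5-(hydroxymethyl)oxolan-2-yl from (2,2-dimethyl-1,3-dioxolan-4-yl)methyl at this position. The entering group has 2 hydrogen-bond donors where the leaving group has 0, and it has 3 defined stereocentres, yet compound 2 and compound 4 remain inseparable on this scale. Nothing available explains this result.

Going by these compounds, whether an amine or a carboxylic acid at this position would also stay within the scatter of compound 2 remains open. Also open, on these data alone, is whether the 3 defined stereocentres of compound 4 have any bearing on its number.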